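Moving the fluorine on the phenylpiperazine

This account rests on a few compounds, and the source may have more. Where it says the series, first, only, none or still open, it means among the compounds named here.

Compounds measured so far in a functional assay on the whole organism (strain CD1) with Mus musculus as the target, in the maximal electroshock model, with a stated time of 4 h; a lower number here means that less compound is needed, a higher number that more compound is needed for the effect:
Compound 1 `CC1CC(=O)N(CC(=O)N2CCN(c3ccc(Cl)cc3)CC2)C1=O`: 30 mg/kg
Compound 2 `CC1CC(=O)N(CC(=O)N2CCN(c3ccccc3F)CC2)C1=O`: 300 mg/kg

Compound 2 stands at the higher of the two numbers, with compound 1 showing the lower one; the step of a 10-fold higher number from compound 1 to compound 2 (1.00 log units; beyond the scatter) separates them. The unmeasured compound 3 `CC1CC(=O)N(CC(=O)N2CCN(c3ccc(F)cc3)CC2)C1=O` differs from compound 2 only in the aryl group: 4-fluorophenyl in place of 2-fluorophenyl on an amine nitrogen in a ring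

Going by the values given here, the one measured step that bears on this change is a 10-fold higher number from compound 1 to compound 2 (1.00 log units; beyond the scatter), in which the aryl group on the ring nitrogen went from 4-chlorophenyl to 2-fluorophenyl and the number rose. Compound 3 keeps a halogen on the phenyl ring in the same place as the chlorine of compound 1, while still carrying fluorine as compound 2 does, so it sits structurally between the two measured compounds. The step to compound 3 is therefore expected to run downward, partly reversing what was seen, and the estimated size is a 3.0-fold lower number from compound 2 to compound 3 (0.48 log units; beyond the scatter). For compound 3 the expected value in this assay is 100 mg/kg, with a likely range from 30 mg/kg to 300 mg/kg.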

Compound 3, minimum effective dose: 100 mg/kg
Estimate against measurement, compound 3: no gap at the digits printed; the range from low to high includes it.
By their numbers in this assay, from the lowest: compound 1; then compound 3; then compound 2.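

With the aryl group's atoms unchanged, 4-fluorophenyl in place of 2-fluorophenyl on the ring nitrogen gives a 3.0-fold lower number from compound 2 to compound 3 (0.48 log units; beyond the scatter) in this assay, so the place of the fluorine alone changes the dose needed. The earlier step could not show this, as it changed the halogen and its place together. Fluoro in place of chloro on an aromatic carbon, with the place held, gives a 3.3-fold higher number from compound 1 to compound 3 (0.52 log units; beyond the scatter), so the identity of the halogen also counts, and the earlier step can now be read as two changes of similar size, each beyond the scatter. No measurement offered here accounts for either step.

The compounds shown leave open whether the order seen among these halogens extends to bromo or methoxy on the phenyl ring, or to a phenyl ring with no substituent at all. They also leave open whether these steps would keep their size and direction if the methyl group on the shared core were replaced by an ethyl group.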